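Adding a third methoxy group to a chalcone-pyrazole

The source may hold more compounds than are shown below. What is called first, only, known or untested is meant among the compounds shown, and "the series" means these compounds.

Compound 3 `COc1ccc(-c2cc(/C=C/C(=O)c3ccc(N)cc3)[nH]n2)cc1OC` and compound 1 `COc1cc(-c2cc(/C=C/C(=O)c3ccc(N)cc3)[nH]n2)cc(OC)c1OC` share a core and differ in one place: methoxy in place of hydrogen on an aromatic carbon. In a functional assay on UACC-62 cells (Homo sapiens) for cytotoxicity, read by sulforhodamine B assay, with a stated time of 48 h, tested at 1 uM (on this read-out lower numbers stand for a stronger effect and higher numbers for a weaker effect at the one concentration tested), compound 3 gives 95%, and compound 1 gives 86%, so the step of a number 9 percentage points lower from compound 3 to compound 1 (within the scatter). Compound 2 `COc1ccc(C(=O)/C=C/c2cc(-c3cc(OC)c(OC)c(OC)c3)n[nH]2)cc1OC` is built on a different core; how its core differs from that of compound 3 is not broken down here. In this assay compound 2 gives 95%, and the step of a number 9 percentage points higher from compound 1 to compound 2 (within the scatter). Compound 4 `COc1cc(C(=O)/C=C/c2cc(-c3cc(OC)c(OC)c(OC)c3)n[nH]2)cc(OC)c1OC` is not yet measured; it differs from compound 2 in exactly the same way, (methoxy in place of hydrogen on an aromatic carbon), with the same surroundings in both cases. Because the earlier step of a number 9 percentage points lower from compound 3 to compound 1 (within the scatter) stayed within the scatter, the step from compound 2 to compound 4 is expected to be a number 5 percentage points lower from compound 2 to compound 4 (within the scatter). Compound 4 is therefore estimated at 90%, likely between 75% and 100%.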

Compound 4, a percentage reported as activity, at one concentration (the size of the read-out at that concentration, not a potency): 90%
For compound 4 middle estimate and measured number coincide at the digits printed; the measured number falls inside the stated range.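

In this assay, putting methoxy in place of hydrogen on an aromatic carbon gives a number 5 percentage points lower from compound 2 to compound 4 (within the scatter), and the steps on the two cores can be set side by side: the same change on two cores in this assay, a number 9 percentage points lower (within the scatter) from compound 3 to compound 1 and a number 5 percentage points lower (within the scatter) from compound 2 to compound 4, 4 percentage points apart, within the scatter of two such steps. On both cores shown, this change therefore gives a step within the scatter, and the two steps agree within the scatter as well. This does not show that the methoxy group has any effect of its own on either core, and a reading at one concentration is not a potency.

The compounds shown leave open whether an amine, a hydroxyl group or a longer alkoxy chain in the same place would give a step beyond the scatter. They also leave open how the methoxy change would behave on any further core.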